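Iodo in place of the carbamoyl group on the shared core

The compounds below may be only part of what the source reports. "The series", "measured", "known", "first", "only" and "open" are said of these compounds alone.

Among the measured compounds shown here, in an assay (Rattus norvegicus) for inhibition of Fatty-acid amide hydrolase 1 (Homo sapiens) (a higher number here means a weaker inhibitor, a lower number a stronger inhibitor), compound 3 `CN(C)C(=O)c1cnc(C(=O)CCCCCCc2ccccc2)o1` gives 2 nM, the second highest of the three numbers measured so far. Compound 2 `COc1ccnc(-c2cnc(C(=O)CCCCCCc3ccccc3)o2)c1` gives 0.8 nM, and compound 1 `Cc1cccnc1-c1cnc(C(=O)CCCCCCc2ccccc2)o1` gives 15 nM. The measured steps are a 19-fold lower number from compound 1 to compound 2 (1.27 log units; beyond the scatter), a 7.5-fold lower number from compound 1 to compound 3 (0.88 log units; beyond the scatter) and a 2.5-fold higher number from compound 2 to compound 3 (0.40 log units; beyond the scatter); each swaps one group on the same aromatic carbon of the shared core. Compound 4 `O=C(CCCCCCc1ccccc1)c1ncc(I)o1` varies that carbon again: iodo in place of dimethylcarbamoyl on an aromatic carbon. For the measured compounds named here, no measured step exchanges a group of this kind for a single atom, so the direction is not settled by the series; the measured steps only show that this position can move the number by modest to large amounts. Loss of the dimethylcarbamoyl group is expected to raise the number, giving a 10-fold higher number from compound 3 to compound 4 (1.00 log units; beyond the scatter). For compound 4 the estimate is 20 nM, within 5 nM to 80 nM.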

Compound 4, inhibition constant: 3 nM
For compound 4 the middle estimate is 6.7-fold (0.82 log units) above the measured one; measured number below the stated range.
By their numbers in this assay, from the lowest: compound 2; then compounds 3 and 4 (each within the scatter of the next); then compound 1.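

At this position, a single iodine atom can stand in for the five heavy atoms of dimethylcarbamoyl, with a 1.5-fold higher number from compound 3 to compound 4 (0.18 log units; within the scatter) in this assay, so that group's carbonyl is not needed for a number in this range. Iodo also stays within the range set by the two pyridinyl groups, with a 3.8-fold higher number from compound 2 to compound 4 (0.57 log units; beyond the scatter) and a 5.0-fold lower number from compound 1 to compound 4 (0.70 log units; beyond the scatter). No evidence at hand bears on why this exchange changes the number so little.

Open, on these data alone, is whether a chloro group, an amine or a carboxylic acid on this carbon would also keep the number in this range.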